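This account rests on a few compounds, and the source may have more. Where it says the series, first, only, none or still open, it means among the compounds named here.

Measured compounds:
compound 1 `CC(=O)Nc1cccc(-c2cc3ncnc(N)c3cc2C(N)=O)c1` — > 50000 nM
compound 2 `NC(=O)c1cc2c(N)ncnc2cc1-c1ccc2cc[nH]c2c1` — > 50000 nM

Both compounds were tested in an assay on isolated protein for inhibition of phosphatidylinositol 4-kinase beta (Homo sapiens), read by luminescence, with a stated time of 60 min; on this read-out higher numbers stand for weaker inhibition and lower numbers for stronger inhibition. In this assay compound 1 gives > 50000 nM, which is a limit of the assay and not a number. Compound 2 likewise returns > 50000 nM in this assay, again a limit. Going by the values given here, compound 1 therefore stands only at the limit of > 50000 nM in this assay, at which 2 of the 2 values shown sit, with no measured number to place it against; the single other value shown is the same limit, so no step between measured compounds can be stated.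

The unmeasured compound 3 `NC(=O)c1cc2c(N)ncnc2cc1-c1cccc(CO)c1` differs from compound 1 in one place: hydroxymethyl in place of acetamido on an aromatic carbon. Since compound 1 sits at a limit, the expected step in this assay is read as a step that the limit leaves unreadable from compound 1 to compound 3, with no grounds to expect a change beyond the scatter. Compound 3 is accordingly estimated at 60000 nM, with a range from 15000 nM to 200000 nM, and most likely the assay again reports only a limit.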

Compound 3, half-maximal inhibitory concentration: > 50000 nM
Compound 3: a limit, no number (the forecaster's own chance of this, stated with the estimate: 80%); the middle value is on the limit's open side.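

Between compound 1 and compound 3 no step can be read in this assay, since neither gives a number, only a limit: the limit of > 50000 nM in this assay, at which 3 of the 3 values shown sit.

The compounds shown leave open how far each lies past that limit, and whether any related compound would give a measurable number in this assay.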